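The compounds below may be only part of what the source reports. "The series", "measured", "known", "first", "only" and "open" are said of these compounds alone.

Measured so far, in a functional assay (Cavia porcellus) with sulfonylurea receptors; K-ATP channels (Homo sapiens) as the target; a higher number here means a weaker inhibitor, a lower number a stronger inhibitor:
compound 1, `COc1ccccc1S(=O)(=O)c1ccc(NC(=O)C(C)(O)C(F)(F)F)cc1`: 1600 nM
compound 2, `CO/N=C(/c1ccccc1)c1ccc(NC(=O)C(C)(O)C(F)(F)F)cc1`: reports only the limit > 30000 nM
compound 3, `CC(O)(C(=O)Nc1ccc(C(O)c2ccccc2)cc1)C(F)(F)F`: reports only the limit > 30000 nM

Going by the values given here, compound 1 is the only compound in this assay that gives a number at all; the other two values sit at the limit of > 30000 nM in this assay, at which 2 of the 3 values shown sit, so no measured step is available for comparison. Compound 4, `CC(O)(C(=O)Nc1ccc(S(=O)(=O)c2cnccn2)cc1)C(F)(F)F`, keeps the sulfonyl of compound 1 and exchanges the group on it: pyrazin-2-yl in place of 2-methoxyphenyl on a sulfonyl sulfur. Among the compounds with values here, no pair of measured compounds covers this exchange. In this assay a moderate weakening is expected for compound 4, a step beyond the usual scatter but well short of the limit. The expected step is a 2.5-fold higher number from compound 1 to compound 4 (0.40 log units; beyond the scatter). Compound 4 is estimated at 4000 nM, in the range 800 nM to 20000 nM.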

Compound 4, half-maximal inhibitory concentration: 12000 nM
Beside the measured number, compound 4's estimate is 3.0-fold (0.48 log units) below it; the range from low to high includes it.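

In this assay, going by these compounds alone, the group on the sulfonyl sulfur proves able to move the number: pyrazin-2-yl in place of 2-methoxyphenyl gives a 7.5-fold higher number from compound 1 to compound 4 (0.88 log units; beyond the scatter) and supplies the first measured step. Compound 4 still gives a number and does not sit at the limit: the limit of > 30000 nM in this assay, at which 2 of the 4 values shown sit.

This single exchange cannot separate the loss of the methoxy group from the entry of the ring nitrogens. Plain phenyl or pyridin-2-yl on the same sulfur would divide the two.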